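The source may hold more compounds than are shown below. What is called first, only, known or untested is meant among the compounds shown, and "the series" means these compounds.

Working notes on the series, following the step from compound 3 to compound 4. For the measured compounds named here, in a functional assay on HCT-116 cells (Homo sapiens) for antiproliferative activity, read by MTT assay, with a stated time of 48 h (a lower number here means a stronger inhibitor, a higher number a weaker inhibitor), compound 1 (`COc1ccc(-c2c(Nc3cccc(C(F)(F)F)c3)c3ccccc3oc2=O)cc1`) gives 55700 nM, and this is the only number available so far. Compound 3 (`COc1ccc(-c2c(Nc3ccc(C)cc3)c3ccc(O)cc3oc2=O)cc1`) has no single number to place it: its entry reads "not determined" (no result reported). Compound 2 (`COc1ccc(-c2c(Nc3ccc(C)c(O)c3)c3ccc(O)cc3oc2=O)cc1`) is in the same position, with an entry of "not determined" (no result reported). Compound 3 therefore cannot be ranked against compound 1.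

Compound 4 (`COc1ccc(-c2c(Nc3cccc(C(F)(F)F)c3)c3ccc(O)cc3oc2=O)cc1`) is still to be measured in this assay. The structural change is 3-(trifluoromethyl)phenyl in place of 4-methylphenyl on a nitrogen on an aromatic ring. In words, 3-(trifluoromethyl)phenyl stands in place of 4-methylphenyl on a nitrogen on an aromatic ring.

Going by the values given here, with no measured step and no number for compound 3, the data give no size or direction for this change. No step beyond the usual scatter is expected in this assay, in either direction, and this is an assumption rather than a reading. Among the compounds with values here, the expectation for compound 4 rests on the single value of compound 1 at 55700 nM, so the range is kept wide. The expected value for compound 4 in this assay is estimated at 40000 nM, within an estimated range of 12000 nM to 100000 nM.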

Compound 4, half-maximal inhibitory concentration: 55900 nM
Estimate against measurement, compound 4: 1.4-fold (0.15 log units) below; low and high end bracket the measured number.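

In this assay the series now has its first measured step, a 1.0-fold higher number from compound 1 to compound 4 (0.00 log units; within the scatter), for hydroxy in place of hydrogen on an aromatic carbon of the shared core. With 3-(trifluoromethyl)phenyl on the nitrogen in both compounds, this single change therefore leaves the antiproliferative read-out within the usual scatter, though this is one pair and no general pattern for the hydroxy group follows from it. The change from 4-methylphenyl to 3-(trifluoromethyl)phenyl cannot be read, as compound 3 has no number, and nothing available bears on why the hydroxy step is this small.

On these data alone, whether the hydroxy step would stay within the scatter with 4-methylphenyl on the nitrogen remains open, as does the effect of the additional hydroxy group on that ring in compound 2, which also has no number. The compounds shown also leave open what a methoxy group or an amine would do in place of the hydroxy, and what a carboxylic acid on the ring carried by the nitrogen would do in place of trifluoromethyl.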